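The source may report more compounds than this note shows. Statements on the series, on what has been measured and on what is new or still open speak of the compounds shown alone.

Compound 1 `CCCn1c(N)c(-c2nc3ccccc3[nH]2)c2nc(C#N)c(C#N)nc21` and compound 2 `CCCCn1c(N)c(-c2nc3ccccc3[nH]2)c2nc(C#N)c(C#N)nc21` share one core and differ only in the chain on an aromatic nitrogen. In a functional assay on cells (Homo sapiens) for antiproliferative activity, read by MTT assay, with a stated time of 48 h (on this read-out higher numbers stand for weaker inhibition and lower numbers for stronger inhibition), compound 1 gives > 50000 nM as a limit of the assay and not a number. Compound 2 likewise gives > 50000 nM as a limit and not a number. Compound 2 therefore has no measured potency and stands at the limit of > 50000 nM in this assay, at which 2 of the 2 values shown sit. Among the compounds with values here, the only measured step is a step that the two limits leave unreadable from compound 1 to compound 2, so it offers no size to carry forward.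

Compound 3 `CCN(CC)CCCCn1c(N)c(-c2nc3ccccc3[nH]2)c2nc(C#N)c(C#N)nc21` differs from compound 2 by diethylamino in place of hydrogen on a saturated chain carbon, four bonds along the chain from an aromatic nitrogen, which is diethylamino in place of hydrogen on a saturated chain carbon, four bonds along the chain from an aromatic nitrogen. This change is larger than the methyl step, but no measurement sizes it. Only a tentative move towards stronger inhibition in this assay is expected, and the result may well remain a limit. The estimated move is an at least 1.6-fold lower number from compound 2 to compound 3 (0.22 log units; that floor lies within the scatter) and it is uncertain. In this assay compound 3 is expected near 30000 nM, within an estimated range from 6000 nM to 100000 nM as its ends.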

Compound 3, half-maximal inhibitory concentration: 640 nM
For compound 3 the middle estimate is 47-fold (1.67 log units) above the measured one; the whole stated range lies above it.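

Compound 1 and compound 2, with plain chains on the aromatic nitrogen, gave no measured potency, and the step between them cannot be read: the limit of > 50000 nM in this assay, at which 2 of the 3 values shown sit. Compound 3 shows that this chain is not a silent position in this assay, since diethylamino on a saturated chain carbon, four bonds along the chain from an aromatic nitrogen, brings a value that can be read, with an at least 78-fold lower number from compound 2 to compound 3 (1.89 log units; beyond the scatter) and, measured against the shorter chain, an at least 78-fold lower number from compound 1 to compound 3 (1.89 log units; beyond the scatter). From the compounds shown here alone, both steps are floors set by limits, so the full size of the change remains unknown, but each is large and lies beyond the scatter.

The compounds shown leave open whether the effect needs an amine at the chain end at all, or whether a simple longer chain, a carboxylic acid or a hydroxyl group at the same place would serve as well. They also leave open how a smaller amine such as dimethylamino, a ring amine such as morpholine or piperidine, or a different number of chain carbons before the diethylamino nitrogen would read in this assay.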